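The source may hold more compounds than are shown below. What is called first, only, known or untested is meant among the compounds shown, and "the series" means these compounds.

Series notes, three aryl variants on a shared core. Compound 1 `CCCS(=O)(=O)Nc1ccc(F)c(C(=O)c2n[nH]c3ncc(-c4ccccc4Cl)cc23)c1F` gives 9.3% in an assay for binding affinity to dual specificity mitogen-activated protein kinase kinase 4 (Homo sapiens), read by KINOMEscan, tested at 100 nM; on this read-out higher numbers stand for a weaker effect at the one concentration tested and lower numbers for a stronger effect. Compound 2 `CCCS(=O)(=O)Nc1ccc(F)c(C(=O)c2n[nH]c3ncc(-c4ccccc4OC)cc23)c1F` gives 1.9% in this assay, and compound 3 `CCCS(=O)(=O)Nc1ccc(F)c(C(=O)c2n[nH]c3ncc(-c4ccc(C(C)C)cc4)cc23)c1F` gives 17% in this assay. Compound 3 holds the highest of the three numbers: the step of a number 7.7 percentage points higher from compound 1 to compound 3 (within the scatter) stays within the scatter, while the step of a number 15.1 percentage points higher from compound 2 to compound 3 (beyond the scatter) goes beyond it, so only against compound 2 is compound 3 clearly the weaker binder at the tested concentration.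

Compound 4 `CCCS(=O)(=O)Nc1ccc(F)c(C(=O)c2n[nH]c3ncc(-c4ccc(S(=O)(=O)NCC)cc4)cc23)c1F` is the next structure, not yet measured. It differs from compound 3 in one place: ethylsulfamoyl in place of isopropyl on an aromatic carbon. Within the data shown here, no measured step in this set exchanges a substituent on that aryl ring for one carrying a hydrogen-bond donor and acceptors, so the change has no direct precedent here. The steps that do bear on it, a number 7.7 percentage points higher from compound 1 to compound 3 (within the scatter) and a number 15.1 percentage points higher from compound 2 to compound 3 (beyond the scatter), show that swapping the aryl substituent shifts this assay by amounts near or just beyond the scatter, in either direction. No step beyond the scatter is expected, with a slight lean toward a lower number. Compound 4 is therefore expected to give 13% in this assay, within a range from 3% to 40%. This corresponds to an expected step of a number 4 percentage points lower from compound 3 to compound 4 (within the scatter), inside the scatter.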

Compound 4, a percentage reported as activity, at one concentration (the size of the read-out at that concentration, not a potency): 3%
Compound 4: middle estimate off by 10 percentage points, on the high side; the measured number falls inside the stated range.
By their numbers in this assay, from the lowest: compounds 2, 4, 1 and 3 (each within the scatter of the next, the first and the last beyond it).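

In this assay, ethylsulfamoyl on the aromatic carbon that carried isopropyl brings a clear move (a number 14 percentage points lower from compound 3 to compound 4 (beyond the scatter)), so a substituent at this place can lower the number as well as raise it. Compound 3 had been the only 4-substituted phenyl, and it held the highest number, but 4-(ethylsulfamoyl)phenyl shows that this substitution does not by itself separate a compound from those with 2-methoxyphenyl (a number 1.1 percentage points higher from compound 2 to compound 4 (within the scatter)) or 2-chlorophenyl (a number 6.3 percentage points lower from compound 1 to compound 4 (within the scatter)). Nothing available explains the drop from isopropyl to ethylsulfamoyl.

From the compounds shown here alone, whether the lower number goes with the sulfamoyl unit or with the ethyl on its nitrogen stays open. An unsubstituted sulfamoyl, a longer chain on that nitrogen, or a carboxylic acid at the same aromatic carbon would help separate these readings.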